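The source may report more compounds than this note shows. Statements on the series, on what has been measured and on what is new or still open speak of the compounds shown alone.

In a functional assay on DLD-1 cells (Homo sapiens) for inhibition, read by luminescence, with a stated time of 3 days (a higher number here means a weaker inhibitor of growth, a lower number a stronger inhibitor of growth), compound 1 `CC(C)C1=C(C(=O)N2[C@H](C)CC[C@H]2C(=O)N2CCN(C)CC2)SC2=N[C@@](C)(c3ccc(Cl)cc3)[C@@H](c3ccc(Cl)cc3)N21` gives 9000 nM, compound 2 `CC[C@@H]1CC[C@@H](C(=O)N2CCN(C)CC2)N1C(=O)C1=C(C(C)C)N2C(=N[C@@](C)(c3ccc(Cl)cc3)[C@H]2c2ccc(Cl)cc2)S1` gives 4000 nM and compound 3 `CC(C)C1=C(C(=O)N2[C@H](C)CC[C@H]2C(=O)N2CCN(C)C(C)(C)C2)SC2=N[C@@](C)(c3ccc(Cl)cc3)[C@@H](c3ccc(Cl)cc3)N21` gives 6300 nM. Compound 2 therefore stands clearly below compound 1, while its number and that of compound 3 lie within the usual scatter of each other.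

Compound 4 `CC[C@@H]1CC[C@@H](C(=O)N2CCN(C)[C@@H](C)C2)N1C(=O)C1=C(C(C)C)N2C(=N[C@@](C)(c3ccc(Cl)cc3)[C@H]2c2ccc(Cl)cc2)S1` differs from compound 2 by a single change: methyl in place of hydrogen on a saturated ring carbon. In words, this is methyl in place of hydrogen on a saturated ring carbon, turning 4-methylpiperazin-1-yl into 3,4-dimethylpiperazin-1-yl.

Among the measured compounds shown here, the closest precedent is a change to the same group on the carbonyl carbon, which gave a 1.4-fold lower number from compound 1 to compound 3 (0.15 log units; within the scatter). A methyl added elsewhere, on a saturated chain carbon, gave a 2.3-fold lower number from compound 1 to compound 2 (0.35 log units; beyond the scatter), which is a modest step. Neither step is large, so no change beyond the scatter is expected in this assay. The expected step is a 1.1-fold lower number from compound 2 to compound 4 (0.06 log units; within the scatter). Compound 4 is estimated at 3500 nM, with an expected range of 1700 nM to 7000 nM.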

Compound 4, concentration for 50% growth inhibition in the DLD-1 assay: 3900 nM
Compound 4: the middle estimate sits 1.1-fold (0.05 log units) below what was measured; measured number inside the range.
By their numbers in the DLD-1 assay, from the lowest: compounds 4, 2, 3 and 1 (each within the scatter of the next, the first and the last beyond it).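

Among the compounds shown here, in the DLD-1 assay a single methyl on this saturated ring carbon gives a 1.0-fold lower number from compound 2 to compound 4 (0.01 log units; within the scatter) and so leaves growth inhibition unchanged, which shows that 3,4-dimethylpiperazin-1-yl can replace 4-methylpiperazin-1-yl here on the scaffold of compound 2, not only that a larger group can be accepted on the carbonyl carbon, with a 1.4-fold lower number from compound 1 to compound 3 (0.15 log units; within the scatter). The new information comes from a physicochemical assay for solubility, read by HPLC, in phosphate buffer, at pH 6.8 (a lower number here means a less soluble compound, a higher number a more soluble compound), where compound 2 gives 13 ug/mL and compound 4 gives 16 ug/mL. the physicochemical assay also stays put, with a 1.2-fold higher number from compound 2 to compound 4 (0.09 log units; within the scatter) as the same change is made, so neither read-out tells these two compounds apart. Nothing measured here accounts for why this methyl makes so little difference.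

As far as these compounds go, whether a longer chain such as ethyl, or a hydroxyl group, would be accepted on this same ring carbon remains open. So does the effect of the methyl with the opposite spatial arrangement at that carbon.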